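The source may report more compounds than this note shows. Statements on the series, on what has been measured and on what is new or still open speak of the compounds shown alone.

Measured compounds in a functional assay on MCF7 cells (Homo sapiens) for cytotoxicity, read by MTT assay, with a stated time of 48 h; a higher number here means a weaker inhibitor, a lower number a stronger inhibitor:
Compound 1 `CCN(CC)c1ccc2cc(C(=O)c3ccc(N4CCN(C(=O)CN5CCN(S(=O)(=O)c6ccc(OC(F)(F)F)cc6)CC5)CC4)cc3)oc2c1` gives 20100 nM.
Compound 2 `CCN(CC)c1ccc2cc(C(=O)c3ccc(N4CCN(C(=O)CN5CCN(S(=O)(=O)c6ccc(C(F)(F)F)cc6)CC5)CC4)cc3)oc2c1` gives 17500 nM.
Compound 3 `C#CCN1CCN(CC(=O)N2CCN(c3ccc(C(=O)c4cc5ccc(N(CC)CC)cc5o4)cc3)CC2)CC1` gives only a limit, > 40000 nM.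

Compound 3 thus stands at the limit of > 40000 nM in this assay, at which 1 of the 3 values shown sits, and no number is known for it. Compound 4 `CCOC(=O)CN1CCN(CC(=O)N2CCN(c3ccc(C(=O)c4cc5ccc(N(CC)CC)cc5o4)cc3)CC2)CC1` differs from compound 3 in one place: ethoxycarbonyl in place of ethynyl on a saturated chain carbon bound to an amine nitrogen in a ring. Among the compounds with values here, the only measured step, a 1.1-fold lower number from compound 1 to compound 2 (0.06 log units; within the scatter), concerns a different part of the shared core and does not bear on this change. Nothing measured speaks to the size or direction of the step in this assay from compound 3 to compound 4, and with compound 3 itself a limit the step cannot be sized. Compound 4 is therefore estimated at 40000 nM, with a range from 15000 nM to 100000 nM, which means an expected step of a number no higher from compound 3 to compound 4 (the limit leaves the size open).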

Compound 4, half-maximal inhibitory concentration: > 40000 nM
Compound 4: only a limit was reported; the forecaster's own chance of this, stated with the estimate: 50%; the middle value lies on the limit itself.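

No step can be read from compound 3 to compound 4, since each carries only a limit in this assay: the limit of > 40000 nM in this assay, at which 2 of the 4 values shown sit. Left open is whether ethoxycarbonyl in place of ethynyl moves the number at all, and in which direction.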